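The compounds below may be only part of what the source reports. "The series", "measured", "known", "first", "only" and "open" are said of these compounds alone.

Measured compounds:
compound 1 `COc1ccc(Nc2nc(SCc3cn(Cc4ccccc4Cl)nn3)nc(-c3ccccc3)c2C#N)cc1`: 7960 nM
compound 2 `N#Cc1c(Nc2cccc(Cl)c2)nc(SCc2cn(Cc3ccccc3Cl)nn2)nc1-c1ccccc1`: 24400 nM
compound 3 `Cc1ccc(Nc2nc(SCc3cn(Cc4ccccc4Cl)nn3)nc(-c3ccccc3)c2C#N)cc1`: a limit, see below

These results come from a functional assay on ECa-109 cells (Homo sapiens) for inhibition, read by MTT assay, with a stated time of 72 h; on this read-out lower numbers stand for stronger inhibition and higher numbers for weaker inhibition. For compound 3 the assay reports only a limit, > 64000 nM, not a number. For the measured compounds named here, compound 3 is the one compound that sits at the limit of > 64000 nM in this assay, at which 1 of the 3 values shown sits.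

Compound 4 `Cc1ccc(Nc2nc(SCc3cn(Cc4ccccc4Cl)nn3)nc(-c3ccc(C(C)C)cc3)c2C#N)cc1` differs from compound 3 in one place: isopropyl in place of hydrogen on an aromatic carbon. The measured steps, a 3.1-fold higher number from compound 1 to compound 2 (0.49 log units; beyond the scatter), an at least 8.0-fold higher number from compound 1 to compound 3 (0.90 log units; beyond the scatter) and an at least 2.6-fold higher number from compound 2 to compound 3 (0.41 log units; beyond the scatter), all alter the group on the nitrogen, not the phenyl ring that gains the isopropyl, so none bears directly on this change. With compound 3 already at the limit, compound 4 is expected to remain near it, an expected step that the limit leaves unreadable from compound 3 to compound 4. In this assay compound 4 is estimated at 80000 nM, with a range from 20000 nM to 300000 nM.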

Compound 4, half-maximal inhibitory concentration: 5080 nM
For compound 4 the middle estimate is 16-fold (1.20 log units) above the measured one, and the stated range ends above it.
By their numbers in this assay, from the lowest: compounds 4 and 1 (each within the scatter of the next); then compound 2. At a limit, above all of these: compound 3.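

In this assay the change from phenyl to 4-isopropylphenyl gives an at least 12-fold lower number from compound 3 to compound 4 (1.10 log units; beyond the scatter) and so shows that the ring carrying this group matters, not only the group on the nitrogen. The true size of this step cannot be read because compound 3 gives only a limit: the limit of > 64000 nM in this assay, at which 1 of the 4 values shown sits.

From the compounds shown here alone, whether a methyl, a longer chain or an amine at this place would do the same stays open. So does whether isopropyl would act alike with the 4-methoxyphenyl group of compound 1 on the nitrogen.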